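Swapping a Carboxylic Acid for a Tetrazole Ring

The source may report more compounds than this note shows. Statements on the series, on what has been measured and on what is new or still open speak of the compounds shown alone.

Among the measured compounds shown here, compound 1 `O=C(O)CC1CCCC1Cc1ccc(OCc2ccc3ccccc3n2)cc1` is the weaker of the two compounds measured so far in an assay on membranes from lung (Cavia porcellus) for binding affinity to cysteinyl leukotriene receptor (Homo sapiens); on this read-out lower numbers stand for stronger inhibition and higher numbers for weaker inhibition: compound 1 gives 100 nM, the highest of the two numbers. Its nearest neighbour, compound 2 `CCCC(CCC(=O)O)Cc1ccc(OCc2ccc3ccccc3n2)cc1`, carries a 1-(2-carboxyethyl)butyl chain in place of the 2-(carboxymethyl)cyclopentyl group, and in this assay compound 2 gives 21 nM, so a 4.8-fold lower number from compound 1 to compound 2 (0.68 log units; beyond the scatter).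

Compound 3 `c1ccc2nc(COc3ccc(CC4CCCC4Cc4nnn[nH]4)cc3)ccc2c1` differs from compound 1 at a different spot: 1H-tetrazol-5-yl in place of carboxy on a saturated chain carbon bound to a saturated ring carbon. The acid group itself is exchanged while the cyclopentane ring and the rest of the shared core remain unchanged.

For the measured compounds named here, no measured step bears on this exchange. Going by the values given here, the single measured step, from compound 1 to compound 2, alters the saturated chain while leaving the acid in place, so it tells nothing about replacing the acid with a tetrazole. In the absence of a comparable step, compound 3 is expected to lie close to compound 1, with a 1.7-fold lower number from compound 1 to compound 3 (0.22 log units; within the scatter) being the estimated step. The estimate for compound 3 in this assay is therefore 60 nM, within a range from 15 nM to 250 nM.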

Compound 3, inhibition constant: 15 nM
Compound 3: the middle estimate sits 4.0-fold (0.60 log units) above what was measured, and the stated range covers the measured number.
By their numbers in this assay, from the lowest: compounds 3 and 2 (each within the scatter of the next); then compound 1.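

The exchange shows that, on this saturated chain carbon bound to a saturated ring carbon, the carboxy group can give way to another group without a loss in this assay: placing 1H-tetrazol-5-yl there gives a 6.7-fold lower number from compound 1 to compound 3 (0.82 log units; beyond the scatter). Among the compounds shown here, the earlier step changed the chain and kept the carboxy group, so this is the first measured change of the acid group itself, and the number falls even though the entering group is larger, with 5 heavy atoms against 3, and brings a five-membered aromatic ring where there was none. Nothing available here accounts for the lower number, so neither the added ring nor the additional hydrogen-bond acceptors can be credited with it.

Going by these compounds, it remains open whether the same exchange would give a similar step on the 1-(2-carboxyethyl)butyl chain of compound 2, which still carries the carboxy group. On these data alone, it is also open how a methyl ester, a primary amide or a sulfonamide would fare at this place, and whether a longer chain leading to the 1H-tetrazol-5-yl group would keep the lower number.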